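The compounds below may be only part of what the source reports. "The series", "measured", "known", "first", "only" and "open" are said of these compounds alone.

Three related molecules built on a shared core were tested in an ADME assay on HEK293 cells (Homo sapiens) for cytotoxicity, read by CCK-8 assay, with a stated time of 4 days; on this read-out higher numbers stand for weaker inhibition and lower numbers for stronger inhibition. Compound 1 `Oc1cccc(-c2cc(-c3ccccc3O)nc(-c3ccccc3O)c2)c1` gives 80 nM. Compound 2 `Oc1ccc(-c2cc(-c3ccccc3O)cc(-c3ccccc3O)n2)cc1` gives 6990 nM, a far higher number than compound 1. Compound 3 `Oc1ccc(-c2cc(-c3cccc(O)c3)cc(-c3ccccc3O)n2)cc1` gives > 50000 nM, which is a limit of this assay and not a number, a point described by the limit of > 50000 nM in this assay, at which 1 of the 3 values shown sits.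

Two changes among these compounds can be followed directly. The first, (4-hydroxyphenyl in place of 2-hydroxyphenyl on an aromatic carbon), brings an at least 620-fold higher number from compound 1 to compound 3 (2.79 log units; beyond the scatter). The second, from compound 2 to compound 3, is 3-hydroxyphenyl in place of 2-hydroxyphenyl on an aromatic carbon, and it brings an at least 7.1-fold higher number from compound 2 to compound 3 (0.85 log units; beyond the scatter). How the core of compound 1 differs from the core of compound 2 is not broken down here.

Compound 4 `Oc1ccc(-c2cc(-c3ccccc3O)cc(-c3ccc(O)cc3)n2)cc1` has not yet been tested in this assay. It differs from compound 2 by 4-hydroxyphenyl in place of 2-hydroxyphenyl on an aromatic carbon. Among the measured compounds shown here, this is the same kind of change as the one from compound 1 to compound 3, though not the same: around the place of the change, compound 4 carries a group meta to a 4-hydroxyphenyl group, whereas compound 3 carries a group meta to a 3-hydroxyphenyl group. Since the earlier change produced an at least 620-fold higher number from compound 1 to compound 3 (2.79 log units; beyond the scatter), the step from compound 2 to compound 4 is expected to be an 8.6-fold higher number from compound 2 to compound 4 (0.93 log units; beyond the scatter), and compound 4 is estimated at 60000 nM in this assay, most likely reported only as a limit.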

Compound 4, half-maximal inhibitory concentration: 780 nM
Compound 4: the middle estimate sits 77-fold (1.89 log units) above what was measured; measured number below the stated range.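

In this assay, 4-hydroxyphenyl in place of 2-hydroxyphenyl brings a 9.0-fold lower number from compound 2 to compound 4 (0.95 log units; beyond the scatter), meaning stronger inhibition, while the same change on the core of compound 1 weakens it, so the two steps point in opposite directions: the same change on two cores in this assay, an at least 620-fold higher number (2.79 log units; beyond the scatter) from compound 1 to compound 3 and a 9.0-fold lower number (0.95 log units; beyond the scatter) from compound 2 to compound 4, at least 5600-fold (3.74 log units) apart, beyond the scatter of two such steps

The value of compound 3, > 50000 nM, is a limit of the assay and not a number.

These two pairs show that neither the size nor the direction of this change carried over from one core to the other, so the result from one core is a poor guide to the other; they do not show why the cores behave differently, and two pairs are too few to give a rule for the whole series.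

The compounds shown leave open how the same change behaves on further cores, and so whether either direction is the more usual one in this series. They also leave open what happens when the hydroxyl of the 4-hydroxyphenyl group gives way to a different group, such as a methoxy group or an amine, and whether such a replacement would keep the lower number seen for compound 4.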